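The source may hold more compounds than are shown below. What is called first, only, known or untested is meant among the compounds shown, and "the series" means these compounds.

Measured compounds:
compound 1 (`CCCCc1nc(CCC)c(CCC(=O)OCC)c(=O)n1Cc1ccc(-c2ccccc2-c2nnn[nH]2)cc1`): "not determined" (no result reported)
compound 2 (`CCCCc1nc(C)c(CC(=O)N(CC)CC)c(=O)n1Cc1ccc(-c2ccccc2-c2nnn[nH]2)cc1`): 0.089 mg/kg
compound 3 (`CCCc1nc(C)c(CC(=O)N(CC)CC)c(=O)n1Cc1ccc(-c2ccccc2-c2nnn[nH]2)cc1`): "not determined" (no result reported)

For the measured compounds named here, in an in vivo functional assay on the whole organism for inhibition, with Rattus norvegicus as the target (a higher number here means that more compound is needed for the effect, a lower number that less compound is needed), compound 2 gives 0.089 mg/kg as the only number in this small set. Compound 1 and compound 3 have no result, so compound 2 cannot yet be called high or low against its neighbours.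

Compound 4 (`CCCCc1nc(C)c(CC(=O)N2CCC[C@H]2C(N)=O)c(=O)n1Cc1ccc(-c2ccccc2-c2nnn[nH]2)cc1`) keeps the rest of compound 2 and changes one part. It carries 2-carbamoylpyrrolidin-1-yl in place of diethylamino on a carbonyl carbon. The entering group brings a five-membered non-aromatic ring and one defined stereocentre, neither of which is present in the group that leaves.

Going by the values given here, no pair of measured compounds shows what an exchange of this kind does, so the expectation rests on the structural change alone, and it is uncertain. Among the compounds with values here, the only anchor is compound 2 (0.089 mg/kg). By the counts this is a sizeable change, so a moderate rise in the dose needed in this assay is expected, although a result within the usual scatter remains possible. The expected size of the change is a 2.2-fold higher number from compound 2 to compound 4 (0.35 log units; beyond the scatter) and is only an estimate. For compound 4 the estimated value is 0.2 mg/kg, with an expected range from 0.05 mg/kg to 0.8 mg/kg.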

Compound 4, dose for half-maximal effect: 0.023 mg/kg
Compound 4: the middle estimate sits 8.7-fold (0.94 log units) above what was measured, outside the stated range (below it).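

In this assay, the exchange of diethylamino for 2-carbamoylpyrrolidin-1-yl on a carbonyl carbon gives a 3.9-fold lower number from compound 2 to compound 4 (0.59 log units; beyond the scatter), so less compound is needed for the effect, and the change lies beyond the usual scatter. For the compounds shown here, this is the first reading at this position, and it shows that the place tolerates an entering group with more heavy atoms, a five-membered non-aromatic ring, a hydrogen-bond donor, a hydrogen-bond acceptor and a defined stereocentre without any loss in this whole-animal read-out. No measured information is available that explains the lower number.

The entering group changes several things at once, so this single step cannot show which of them matters: plain pyrrolidin-1-yl, without the carbamoyl group, would separate the ring from the carbamoyl group, and the opposite configuration at the stereocentre would test whether that arrangement counts. As far as these compounds go, it also remains open whether a carboxylic acid or a methyl ester in place of the carbamoyl group would keep the lower number seen for compound 4.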